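Ribose-bearing series: difluoromethoxy for chloro on the benzyl ring

The compounds below may be only part of what the source reports. "The series", "measured", "known", "first", "only" and "open" are said of these compounds alone.

Measured so far:
compound 1 `OC[C@H]1O[C@@H](n2cnc3c(NCc4ccccc4Cl)ncnc32)[C@H](O)[C@@H]1O` — a functional assay on G-361 cells (Homo sapiens) for antiproliferative activity, with a stated time of 72 h; a higher number here means a weaker inhibitor, a lower number a stronger inhibitor: "not determined" (no result reported)
compound 2 `OC[C@H]1O[C@@H](n2cnc3c(NCc4cc(O)cc(O)c4)ncnc32)[C@H](O)[C@@H]1O` — this assay : > 166000 nM

For compound 2 the entry in this assay is a limit of the assay, not a number. Compound 1 has no result in this assay, so it stands nowhere on the numbers shown; the only figure is the limit of > 166000 nM in this assay, at which 1 of the 2 values shown sits. Compound 3 `OC[C@H]1O[C@@H](n2cnc3c(NCc4ccccc4OC(F)F)ncnc32)[C@H](O)[C@@H]1O` differs from compound 1 by difluoromethoxy in place of chloro on an aromatic carbon, ortho to a large group. Going by the values given here, no measured step exists between these compounds, so no size or direction of step can be read from the data. Compound 3 is expected to give about 30000 nM in this assay, estimated between 5000 nM and 166000 nM.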

Compound 3, half-maximal inhibitory concentration: > 166000 nM
Compound 3 ended at the assay's limit; the forecaster's own chance of this, stated with the estimate: 35%; at least 5.5-fold (0.74 log units) between middle value and limit.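

Compound 2 and compound 3 both stand at the limit of this assay, so no step between them can be read: the limit of > 166000 nM in this assay, at which 2 of the 3 values shown sit.

The compounds shown leave open how difluoromethoxy compares with chloro on the benzyl ring in this assay.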